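The source may report more compounds than this note shows. Statements on the series, on what has been measured and on what is new or still open speak of the compounds shown alone.

Compound 3 `O=C(Cn1cc(-c2ccncc2)nn1)Nc1nc2ccccc2s1` carries a pyridin-4-yl group on the five-membered ring of the shared core. In a functional assay on BMDM cells (Mus musculus, strain C57BL/6) for inhibition, with a stated time of 2 days (on this read-out higher numbers stand for weaker inhibition and lower numbers for stronger inhibition), compound 3 gives 50 nM, the lowest of the two numbers seen so far. Among the compounds with values here, its nearest neighbour is compound 1 `Nc1cccc(-c2cn(CC(=O)Nc3nc4ccccc4s3)nn2)c1`, which in this assay gives 1110 nM; the step of a 22-fold lower number from compound 1 to compound 3 (1.35 log units; beyond the scatter) is the only measured change at this position. Compound 2 `COC(=O)c1ccc(-c2cn(CC(=O)Nc3nc4ccccc4s3)nn2)cc1` is reported in this assay only as a limit, > 30000 nM, not as a number.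

Compound 4 `O=C(Cn1cc(-c2ccc(F)cc2)nn1)Nc1nc2ccccc2s1` differs from compound 3 in one place: 4-fluorophenyl in place of pyridin-4-yl on an aromatic carbon. The step from compound 1 to compound 3 shows that the pyridin-4-yl ring sits far below the 3-aminophenyl ring, and the two carbon-only rings of compound 1 and compound 2 both stand at weaker values than compound 3. A rise in the number is therefore expected, roughly a 10-fold higher number from compound 3 to compound 4 (1.00 log units; beyond the scatter). Compound 4 is estimated at 500 nM, with a range from 100 nM to 3000 nM.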

Compound 4, half-maximal inhibitory concentration: > 30000 nM
Compound 4: only a limit was reported; the forecaster's own chance of this, stated with the estimate: 10%; middle value at least 60-fold (1.77 log units) from the limit.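

Compound 4 is reported in this assay only as a limit, not as a number: the limit of > 30000 nM in this assay, at which 2 of the 4 values shown sit.

Putting 4-fluorophenyl in place of pyridin-4-yl on this aromatic carbon gives an at least 600-fold higher number from compound 3 to compound 4 (2.77 log units; beyond the scatter), so a carbon-only ring with a fluoro group does not keep the low number of compound 3. The same group in place of 3-aminophenyl gives an at least 27-fold higher number from compound 1 to compound 4 (1.43 log units; beyond the scatter), which shows that a carbon-only ring at this position can still differ widely with what it carries, since compound 1 keeps a measured number.

Compound 2 and compound 4 both stand as limits, so the step between them cannot be read. On these data alone, whether a carboxylic acid, a hydroxyl or a morpholine ring at this position would stay near compound 3 remains open.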